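The source may report more compounds than this note shows. Statements on the series, on what has been measured and on what is new or still open speak of the compounds shown alone.

Measured so far in an assay on isolated protein for inhibition of RAC-alpha serine/threonine-protein kinase (Homo sapiens); a higher number here means a weaker inhibitor, a lower number a stronger inhibitor:
Compound 1 `Cc1cccc(C)c1S(=O)(=O)NC[C@@H](O)CN1CCC[C@@]2(CCN(c3ncnc(N)c3C3CC3)C2)C1` gives 4 nM.
Compound 2 `Cc1ccc(S(=O)(=O)NC[C@@H](O)CN2CCC[C@@]3(CCN(c4ncnc(N)c4C4CC4)C3)C2)c(C)c1` gives 160 nM.

Compound 2 has the higher of the two numbers in this assay, standing a long way from compound 1, as the step of a 40-fold higher number from compound 1 to compound 2 (1.60 log units; beyond the scatter) shows. Compound 3 `Cc1ccncc1S(=O)(=O)NC[C@@H](O)CN1CCC[C@@]2(CCN(c3ncnc(N)c3C3CC3)C2)C1` differs from compound 2 by 4-methylpyridin-3-yl in place of 2,4-dimethylphenyl on a sulfonyl sulfur. Within the data shown here, the only measured step alters this same group on the sulfonyl sulfur and was large, so a sizeable shift in this assay is plausible, yet no measured pair tells its direction; a moderate lowering is estimated for compound 3, a 2.7-fold lower number from compound 2 to compound 3 (0.43 log units; beyond the scatter), giving 60 nM with a range of 10 nM to 400 nM.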

Compound 3, half-maximal inhibitory concentration: 1100 nM
For compound 3 the middle estimate is 18-fold (1.26 log units) below the measured one; the whole stated range lies below it.
By their numbers in this assay, from the lowest: compound 1; then compound 2; then compound 3.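

Replacing 2,4-dimethylphenyl with 4-methylpyridin-3-yl on the sulfonyl sulfur gives a 6.9-fold higher number from compound 2 to compound 3 (0.84 log units; beyond the scatter) in this assay, so the number here depends on the ring itself as well as on how its methyl groups are arranged. Among these compounds, measured against the 2,6-dimethylphenyl of compound 1, the same group gives a 280-fold higher number from compound 1 to compound 3 (2.44 log units; beyond the scatter), the largest step so far. Nothing available explains either step.

Still open, as far as these compounds go, is how a cyclohexyl group or a methoxyphenyl group on the sulfonyl sulfur would compare with the 2,6-dimethylphenyl of compound 1.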